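The source may hold more compounds than are shown below. What is called first, only, known or untested is meant among the compounds shown, and "the series" means these compounds.

Measured in a functional assay on NCI-H226 cells (Homo sapiens) for inhibition, read by MTT assay, with a stated time of 48 h, tested at 10 uM; a higher number here means more inhibition at the concentration tested (going by the name of the read-out), a lower number less inhibition:
- compound 1 `COc1cc(NC(=O)Nc2cc(Nc3cc(Br)ccc3OC)ncn2)cc(OC)c1` gives 42.7%
- compound 2 `COc1ccc(C(F)(F)F)cc1Nc1cc(NC(=O)Nc2c(Cl)cccc2Cl)ncn1` gives 60.1%
- compound 3 `COc1cc(NC(=O)Nc2cc(Nc3cc(I)ccc3OC)ncn2)cc(OC)c1` gives 56.7%

Compound 3 has the second highest of the three numbers in this assay; compound 2 lies within the scatter of it, while compound 1 is lower beyond the scatter. Within the data shown here, the one single-point step measured, iodo in place of bromo on an aromatic carbon, gave a number 14 percentage points higher from compound 1 to compound 3 (beyond the scatter). Compound 4 `COc1cc(NC(=O)Nc2cc(Nc3cc(C(F)(F)F)ccc3OC)ncn2)cc(OC)c1` differs from compound 3 by trifluoromethyl in place of iodo on an aromatic carbon. Among the measured compounds shown here, no measured step exchanges a halogen for a trifluoromethyl group, so the earlier halogen swap bears on it only loosely. Compound 4 is therefore expected to show a number 4.7 percentage points lower from compound 3 to compound 4 (within the scatter), a step not clearly beyond the scatter. Compound 4 is estimated at 52%, between 38% and 66%.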

Compound 4, a percentage reported as inhibition, at one concentration (the size of the read-out at that concentration, not a potency): 60%
Beside the measured number, compound 4's estimate is 8 percentage points below it; the range from low to high includes it.
By their numbers in this assay, from the lowest: compound 1; then compounds 3, 4 and 2 (each within the scatter of the next).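

With trifluoromethyl on this aromatic carbon, para to a methoxy group, this assay gives a number 3.3 percentage points higher from compound 3 to compound 4 (within the scatter) and, set against bromo, a number 17.3 percentage points higher from compound 1 to compound 4 (beyond the scatter), so only bromo stands apart among these three groups here. With trifluoromethyl held in place, exchanging the group on the amide-type nitrogen gives a number 0.1 percentage points lower from compound 2 to compound 4 (within the scatter), and that exchange shows no effect beyond the scatter. Nothing measured here explains these numbers. Going by these compounds, whether an amine or a carboxylic acid on this same carbon would keep the inhibition remains open. So does whether the methoxy group para to it matters.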